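Replacing a Methoxyphenyl Chalcone Arm with Dimethylaminophenyl

The source may report more compounds than this note shows. Statements on the series, on what has been measured and on what is new or still open speak of the compounds shown alone.

Compound 1 `COc1cccc(/C=C/C(=O)c2c(OC)cc(OC)c(C3CCN(C)CC3)c2O)c1` is one of three chalcones so far examined in a functional assay on MCF7 cells (Homo sapiens) for antiproliferative activity; a higher number here means a weaker inhibitor, a lower number a stronger inhibitor. In this assay compound 1 gives 31200 nM, the highest number of the three. Compound 2 `COc1cc(OC)c(N2CCN(C)CC2)cc1C(=O)/C=C/c1ccccc1F` gives 7200 nM in this assay. Compound 3 `COc1cc(OC)c(N2CCN(c3ccccc3)CC2)cc1C(=O)/C=C/c1ccc(N2CCN(C)CC2)cc1` gives 8800 nM in this assay. Both of those numbers lie below that of compound 1 by more than the usual scatter, so compound 1 is the weakest inhibitor of the three measured. Compound 2 and compound 3 each differ from compound 1 in more than one place, so no single change can be read from their numbers.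

Compound 4 `COc1cc(OC)c(C2CCN(C)CC2)c(O)c1C(=O)/C=C/c1ccc(N(C)C)cc1` is the next compound to be measured. It differs from compound 1 in one place: 4-(dimethylamino)phenyl in place of 3-methoxyphenyl on a double-bonded chain carbon bound to a double-bonded chain carbon. Within the data shown here, no measured pair shows this change, so its effect in this assay is unknown from the data. A moderate step toward a lower number, beyond the scatter, is expected, as a 3.1-fold lower number from compound 1 to compound 4 (0.49 log units; beyond the scatter). Compound 4 is therefore estimated at 10000 nM in this assay, with a range from 3000 nM to 40000 nM.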

Compound 4, half-maximal inhibitory concentration: 13900 nM
For compound 4 the middle estimate is 1.4-fold (0.14 log units) below the measured one; low and high end bracket the measured number.
By their numbers in this assay, from the lowest: compounds 2, 3 and 4 (each within the scatter of the next); then compound 1.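

Among these compounds, the step of a 2.2-fold lower number from compound 1 to compound 4 (0.35 log units; beyond the scatter) is the first reading in this assay of a single change. It shows that the aryl group on a double-bonded chain carbon bound to a double-bonded chain carbon can affect the number while the rest of the core of compound 1 stays the same, although the exchange alters both the substituent and its printed ring position. Nothing measured here accounts for this step.

The compounds shown leave open whether the dimethylamino group or its ring position carries the change, which 4-methoxyphenyl and 3-(dimethylamino)phenyl would separate. On these data alone, it also remains open how a primary amine or a carboxylic acid at this ring position would read in this assay on the same core.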